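The compounds below may be only part of what the source reports. "The series", "measured", "known", "first", "only" and "open" are said of these compounds alone.

Of the compounds shown here, three have so far been measured in a functional assay on KYSE-450 cells (Homo sapiens) for inhibition, read by MTT assay, with a stated time of 48 h; a lower number here means a stronger inhibitor, a higher number a weaker inhibitor. Compound 1, `CCC/C=C/C(=O)N(Cc1ccc(OC)c(O)c1)c1cc(OC)c(OC)c(OC)c1`, gives 57 nM, which is the lowest of the three numbers. Compound 2, `C/C=C/C(=O)N(Cc1ccc(OC)c(Br)c1)c1cc(OC)c(OC)c(OC)c1`, gives 10500 nM, and compound 3, `COc1ccc(CNc2cc(OC)c(OC)c(OC)c2)cc1F`, gives 46200 nM; both of these gaps from compound 1 lie well beyond the usual scatter, so compound 1 is the most potent of the three. None of these pairs differs in only one place, so no single change can be read off between them.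

Compound 4, `COc1ccc(CN(C(=O)CBr)c2cc(OC)c(OC)c(OC)c2)cc1O`, is not yet measured. It is built from compound 1 by one change: bromomethyl in place of pent-1-en-1-yl on a carbonyl carbon. The shared core, the side ring and the amide linkage are kept; only the group on the carbonyl carbon is exchanged.

Within the data shown here, with no measured pair showing this kind of exchange, the expectation rests on compound 1 alone. A moderate loss is expected, so the step of a 5.3-fold higher number from compound 1 to compound 4 (0.72 log units; beyond the scatter) is estimated to go toward a higher number, beyond the scatter. Compound 4 is therefore expected to give about 300 nM, within a range from 60 nM to 1500 nM.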

Compound 4, half-maximal inhibitory concentration: 120 nM
Estimate against measurement, compound 4: 2.5-fold (0.40 log units) above; the range from low to high includes it.
By their numbers in this assay, from the lowest: compound 1; then compound 4; then compound 2; then compound 3.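

In this assay, among these compounds, exchanging pent-1-en-1-yl for bromomethyl on the carbonyl carbon gives a 2.1-fold higher number from compound 1 to compound 4 (0.32 log units; beyond the scatter), the first step that can be read at a single place. Although the group shrinks from five heavy atoms to two and loses its double bond, the step stays modest and compound 4 still gives 120 nM, so neither the longer chain nor its double bond is needed for a number this low. Nothing measured here explains the size of this step.

From the compounds shown here alone, whether a plain methyl or a chloromethyl group on this carbonyl carbon would give a number like that of compound 4 remains open. So does how a saturated pentyl chain would compare with pent-1-en-1-yl.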